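The compounds below may be only part of what the source reports. "The series", "measured", "known", "first", "only" and "open" are said of these compounds alone.

Compound 1 `CCn1c(=O)n(C2OC(CO)[C@@H](O)[C@H]2O)c2nc(N)nc(O)c21` gives the highest of the two numbers in a functional assay on the whole organism (B cells) with Mus musculus as the target (on this read-out higher numbers stand for larger maximal responses and lower numbers for smaller maximal responses), namely 82%. Compound 2 `Nc1nc(O)c2c(n1)n(C1OC(CO)[C@@H](O)[C@H]1O)c(=O)n2CC(O)CN1CCN(c2ccc(F)cc2)CC1` gives 16% in this assay and so stands far under compound 1, a gap beyond the scatter, but its substitution differs from compound 1 in more than one way and offers no close guide. Compound 3 `CCCCn1c(=O)n(C2OC(CO)[C@@H](O)[C@H]2O)c2nc(N)nc(O)c21` is not yet measured and differs from compound 1 in a single place: ethyl in place of hydrogen on a saturated chain carbon, two bonds along the chain from an aromatic nitrogen. With nothing of this size measured in the series, the expected step from compound 1 to compound 3 in this assay is a number 12 percentage points lower from compound 1 to compound 3 (beyond the scatter), a small fall near the edge of the scatter. Compound 3 is therefore expected to reach about 70%, within 45% to 90%.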

Compound 3, largest response reached (reported as maximal response), in percent of the reference or control that the assay uses: 86%
For compound 3 the middle estimate is 16 percentage points below the measured one; low and high end bracket the measured number.
By their numbers in this assay, from the lowest: compound 2; then compounds 1 and 3 (each within the scatter of the next).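

In this assay, ethyl in place of hydrogen on a saturated chain carbon, two bonds along the chain from an aromatic nitrogen, gives a number 4 percentage points higher from compound 1 to compound 3 (within the scatter) and so the read-out does not separate the ethyl and butyl compounds. This first single-place step shows that this position accepts the change from ethyl to butyl with no difference beyond the scatter. No evidence on the cause of this result is at hand.

Going by these compounds, whether a longer chain such as hexyl would give the same result remains open. So does the effect of an amine or a carboxylic acid at the end of the chain.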